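The source may report more compounds than this note shows. Statements on the series, on what has been measured and on what is new or still open speak of the compounds shown alone.

In an ADME assay on Huh-7 cells (Homo sapiens) for cytotoxicity, with a stated time of 72 h (a lower number here means that less compound is tolerated, a higher number that more compound is tolerated), compound 1 (`COCCn1nc(-c2cccs2)c(O)c(C2=NS(=O)(=O)c3cc(NS(C)(=O)=O)ccc3N2)c1=O`) gives > 1000 nM, which is a limit of the assay. Compound 2 (`CS(=O)(=O)Nc1ccc2c(c1)S(=O)(=O)N=C(c1c(O)c(-c3cccs3)nn(CC3CC3)c1=O)N2`) gives > 1000 nM, which is also a limit and not a number. Within the data shown here, the only measured step is a step that the two limits leave unreadable from compound 1 to compound 2, so the record offers just (the limit of > 1000 nM in this assay, at which 2 of the 2 values shown sit). Compound 3 (`CS(=O)(=O)Nc1ccc2c(c1)S(=O)(=O)N=C(c1c(O)c(-c3cccs3)nn(CC3(C(F)(F)F)CC3)c1=O)N2`) differs from compound 2 by trifluoromethyl in place of hydrogen on a saturated ring carbon, with trifluoromethyl in place of hydrogen on a saturated ring carbon. Among the measured compounds shown here, no measured step bears on this change, so no shift beyond the scatter is expected. The expected step is a step that the limit leaves unreadable from compound 2 to compound 3. The estimate for compound 3 is 1500 nM, within an expected range from 700 nM to 5000 nM.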

Compound 3, half-maximal cytotoxic concentration: > 1000 nM
Compound 3: a limit, no number; the forecaster's own chance of this, stated with the estimate: 85%; the middle value is on the limit's open side.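

Compound 3, like compound 1 and compound 2, stands at a limit in this assay, so no step among these compounds can be read: the limit of > 1000 nM in this assay, at which 3 of the 3 values shown sit.

What the compounds shown leave open is where the actual tolerated concentration of each one lies, and whether the changes among them shift it at all.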